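The source may hold more compounds than are shown below. What is called first, only, known or untested is meant among the compounds shown, and "the series" means these compounds.

Of the compounds shown here, two have been measured in an assay for inhibition of MAP kinase-interacting serine/threonine-protein kinase 2 (Homo sapiens), read by TR-FRET; a higher number here means a weaker inhibitor, a lower number a stronger inhibitor. Compound 1 `CCn1cc(-c2ccnc(Nc3ccc(OC)cc3OC)n2)c2ccccc21` gives 430 nM in this assay. Compound 2 `COCCSc1nc(C)c(-c2ccnc(Nc3ccc(OC)cc3OC)n2)s1` gives 1700 nM in this assay, which is the higher of the two numbers, so compound 2 is the weaker inhibitor of the pair; the gap to compound 1 lies beyond the scatter, while compound 1 sits on the stronger side. No single-point comparison between the two measured compounds is available, so the move to the new compound cannot lean on a matching precedent.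

Compound 3 `COc1ccc(Nc2nccc(-c3sc(SCCCN(C)C)nc3C)n2)c(OC)c1` keeps everything of compound 2 except one change on its side chain: (dimethylamino)methyl in place of methoxy on a saturated chain carbon, two bonds along the chain from a sulfur. The change sits away from the shared core, on the chain that hangs from the sulfur.

Going by the values given here, with no comparable step on record, the expected change from compound 2 to compound 3 in this assay is estimated as small, a 1.4-fold lower number from compound 2 to compound 3 (0.15 log units; within the scatter), and not clearly beyond the scatter in either direction. Compound 3 is therefore expected to give about 1200 nM in this assay, with a range from 400 nM to 3500 nM.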

Compound 3, inhibition constant: 1150 nM
Beside the measured number, compound 3's estimate is 1.0-fold (0.02 log units) above it, and the stated range covers the measured number.
By their numbers in this assay, from the lowest: compound 1; then compounds 3 and 2 (each within the scatter of the next).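

In this assay, replacing the (2-methoxyethyl)sulfanyl group with (3-(dimethylamino)propyl)sulfanyl gives a 1.5-fold lower number from compound 2 to compound 3 (0.17 log units; within the scatter), so the two compounds cannot be told apart in this assay. Going by these compounds alone, this is the first direct comparison at this position, and it shows that the end of the chain hanging from the sulfur can change from a methoxy group to a larger dimethylamino-bearing group with no change in the number beyond the ordinary variation between repeat measurements. A single swap at one position cannot establish a general rule, however, and no other measurement here helps to interpret why these two groups read alike.

The compounds shown leave open whether other groups at the end of this chain, such as a morpholine, a carboxylic acid or a simple hydroxyl, would also leave the number within that variation. They also leave open how much the chain itself contributes, which a shorter chain, a longer chain or a plain methyl group on the sulfur could test while the rest of compound 3 stays fixed.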